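Naphthyl for ethylphenyl: a step from compound 2

A few compounds are considered here, and "the series" means these few. Any claim that something is new, unique, unknown or untested is made for them only; others in the source may bear on it.

Compound 1, `Brc1ccc(-c2cn3ccnc3c(-c3ccc4ncn(C5CCCCC5)c4c3)n2)cc1`: 32.1%
Compound 2, `CCc1ccc(-c2cn3ccnc3c(-c3ccc4ncn(Cc5ccccc5)c4c3)n2)cc1`: 55.4%

Two compounds were tested in a functional assay on RPMI-8226 cells (Homo sapiens) for inhibition, read by sulforhodamine B assay, with a stated time of 48 h, tested at 10 uM; a lower number here means less inhibition, a higher number more inhibition at the concentration tested (going by the name of the read-out). Compound 1 gives 32.1%. Compound 2 reaches 55.4%, the higher of the two numbers, and its distance from compound 1 lies beyond the usual scatter. The two compounds differ in more than one place, so no single change can be tied to that gap.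

Compound 3, `c1ccc(Cn2cnc3ccc(-c4nc(-c5cccc6ccccc56)cn5ccnc45)cc32)cc1`, keeps the benzyl-bearing core of compound 2 and changes one group: naphthalen-1-yl in place of 4-ethylphenyl on an aromatic carbon. Within the data shown here, no measured pair shows the effect of such a change, so the size of the step from compound 2 is uncertain. Compound 3 is expected to land near compound 2, with a step in this assay of a number 5.4 percentage points lower from compound 2 to compound 3 (within the scatter), possibly within the scatter. Compound 3 is therefore estimated at 50%, in a range from 25% to 75%.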

Compound 3, a percentage reported as inhibition, at one concentration (the size of the read-out at that concentration, not a potency): 26.9%
Beside the measured number, compound 3's estimate is 23.1 percentage points above it; low and high end bracket the measured number.
By their numbers in this assay, from the lowest: compounds 3 and 1 (each within the scatter of the next); then compound 2.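

Among these compounds, with the benzyl-bearing core held fixed, naphthalen-1-yl in place of 4-ethylphenyl gives the first comparison in this assay that differs in one place only, with a number 28.5 percentage points lower from compound 2 to compound 3 (beyond the scatter). The number at this aromatic carbon, next to the ring nitrogen, therefore depends on which carbon-only aromatic group sits there, and a change from one such group to another can move it beyond the scatter. No measurement here accounts for the size of this step.

Going by these compounds, it remains open whether an unsubstituted phenyl, a naphthalen-2-yl or a 4-aminophenyl group at this position would read closer to compound 2 or to compound 3. On these data alone, it is also open whether the same change would give a similar step with cyclohexyl in place of benzyl on the core.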